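From fluoro to isopropoxy on the shared core

The source may report more compounds than this note shows. Statements on the series, on what has been measured and on what is new or still open speak of the compounds shown alone.

Measured in an ADME assay on KB cells (Homo sapiens) for cytotoxicity, read by MTT assay, with a stated time of 72 h; on this read-out lower numbers stand for stronger inhibition and higher numbers for weaker inhibition:
- Compound 1 `COc1ccc(C2=C(c3cc(OC)c(OC)c(OC)c3)C(=O)C(O)C2)cc1`: < 1 ug/mL, a limit of the assay
- Compound 2 `COc1ccc(C2=C(c3cc(OC)c(OC)c(OC)c3)C(=O)C(O)C2)cc1Cl`: 2.5 ug/mL
- Compound 3 `COc1ccc(C2=C(c3cc(OC)c(OC)c(OC)c3)C(=O)C(O)C2)cc1F`: 4.5 ug/mL

Compound 3 stands level with compound 2, as a 1.8-fold higher number from compound 2 to compound 3 (0.26 log units; within the scatter) lies within the scatter. Both sit clearly apart from compound 1, whose value is only a limit. The next analogue, compound 4 `COc1ccc(C2=C(c3cc(OC)c(OC)c(OC)c3)C(=O)C(O)C2)cc1OC(C)C`, carries isopropoxy in place of fluoro on an aromatic carbon.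

Among the measured compounds shown here, two measured steps bear on this change at the same carbon, an at least 2.5-fold higher number from compound 1 to compound 2 (0.39 log units; beyond the scatter) and an at least 4.5-fold higher number from compound 1 to compound 3 (0.65 log units; beyond the scatter), both beyond the scatter. Their sizes are minimum sizes because of the limit of < 1 ug/mL in this assay, at which 1 of the 3 values shown sits. Chloro and fluoro, the two substituents measured there, do not separate from each other, so compound 4 is expected to stay near them in this assay. No isopropoxy group has been measured in this set, so the expectation is loose.

The estimate means a 1.5-fold lower number from compound 3 to compound 4 (0.18 log units; within the scatter), which is no expected step beyond the scatter. For compound 4 the estimated value is 3 ug/mL, with an expected range from 0.9 ug/mL to 10 ug/mL.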

Compound 4, half-maximal inhibitory concentration: > 100 ug/mL
Compound 4: a limit, no number (the forecaster's own chance of this, stated with the estimate: 20%); middle value at least 33-fold (1.52 log units) away from the limit.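

In this assay compound 4 gives > 100 ug/mL, which is a limit of the assay and not a number. Chloro and fluoro at this aromatic carbon had not separated from each other, yet isopropoxy splits sharply from both, with an at least 22-fold higher number from compound 3 to compound 4 (1.34 log units; beyond the scatter) and an at least 40-fold higher number from compound 2 to compound 4 (1.60 log units; beyond the scatter), and it also lies far from the unsubstituted compound, with an at least 100-fold higher number from compound 1 to compound 4 (2.00 log units; beyond the scatter). So the position does not respond alike to every replacement of hydrogen, and these steps give only minimum sizes because the value of compound 4 is capped: the limit of > 100 ug/mL in this assay, at which 1 of the 4 values shown sits.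

The compounds shown leave open where between fluoro and isopropoxy the loss sets in, since neither ethoxy nor a hydroxyl group appears at this carbon. They also leave open how an amine there would compare with compound 2 and compound 3.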